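This account rests on a few compounds, and the source may have more. Where it says the series, first, only, none or still open, it means among the compounds named here.

In a functional assay on L1210 cells (Mus musculus) for antiproliferative activity, with a stated time of 48 h (on this read-out higher numbers stand for weaker inhibition and lower numbers for stronger inhibition), compound 1 (`C=C(Br)C(=O)Nc1ccc(/C=C/C(=O)c2ccc(F)cc2)cc1`) gives 1600 nM and compound 2 (`C=C(Br)C(=O)Nc1ccc(/C=C/C(=O)c2ccc(Br)cc2)cc1`) gives 620 nM, which is a 2.6-fold lower number from compound 1 to compound 2 (0.41 log units; beyond the scatter). Compound 3 (`C=C(Br)C(=O)Nc1ccc(/C=C/C(=O)c2ccc(OC)cc2)cc1`) gives 980 nM and stands within the scatter of both others, with a 1.6-fold lower number from compound 1 to compound 3 (0.21 log units; within the scatter) on one side and a 1.6-fold higher number from compound 2 to compound 3 (0.20 log units; within the scatter) on the other. Compound 4 (`C=C(Br)C(=O)Nc1ccc(/C=C/C(=O)c2cccc(OC)c2)cc1`) has the same atoms as compound 3, joined differently: 3-methoxyphenyl in place of 4-methoxyphenyl on a carbonyl carbon. For the measured compounds named here, no measured step tests this kind of change, since all three exchange one group for another and none moves the methoxy. Going by the values given here, they are the only guide, and the largest of them, between compound 1 and compound 2, is a modest 2.6-fold lower number from compound 1 to compound 2 (0.41 log units; beyond the scatter). A shift beyond the scatter is therefore not expected in either direction, although the data cannot rule one out. The expected outcome is a 1.0-fold higher number from compound 3 to compound 4 (0.01 log units; within the scatter), with no firm direction implied. Compound 4 is estimated at 1000 nM, with an expected range of 450 nM to 2200 nM.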

Compound 4, half-maximal inhibitory concentration: 2100 nM
Beside the measured number, compound 4's estimate is 2.1-fold (0.32 log units) below it; measured number inside the range.
By their numbers in this assay, from the lowest: compounds 2, 3, 1 and 4 (each within the scatter of the next, the first and the last beyond it).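

In this assay, for the compounds shown here, the change from 4-methoxyphenyl to 3-methoxyphenyl on a carbonyl carbon is the first here that keeps the group and alters only where it sits, and it gives a 2.1-fold higher number from compound 3 to compound 4 (0.33 log units; beyond the scatter). Against the other two compounds, the 3-methoxyphenyl compound shows a 3.4-fold higher number from compound 2 to compound 4 (0.53 log units; beyond the scatter) and a 1.3-fold higher number from compound 1 to compound 4 (0.12 log units; within the scatter), so a move of the methoxy alone can produce a step beyond the scatter, as the exchange of fluoro for bromo did. No measurement given here accounts for this shift.

Going by these compounds, whether 3-bromophenyl or 3-fluorophenyl would give a like step against their 4-substituted counterparts remains open. Also open, on these data alone, is what an amine or a carboxylic acid on this ring would do in place of the methoxy.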